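The compounds below may be only part of what the source reports. "The series", "measured", "known", "first", "only" and "open" are said of these compounds alone.

Measured in a functional assay on CLL cells (Homo sapiens) for cytotoxicity, read by MTT assay, with a stated time of 48 h; on this read-out lower numbers stand for an effect already at smaller amounts and higher numbers for an effect only at larger amounts of compound:
- compound 1 `C=C(CC)C(=O)c1ccc(OCC(=O)Nc2ccc(C(=O)O)c(O)c2)c(Cl)c1Cl`: > 25000 nM (a limit of the assay)
- compound 2 `C=C(CC)C(=O)c1ccc(OCC(=O)NC(CS)C(=O)OCC)c(Cl)c1Cl`: 4800 nM
- compound 3 `C=C(CC)C(=O)c1ccc(OCC(=O)Nc2ccc3c(c2)C(O)N=NC3O)c(Cl)c1Cl`: 8500 nM

In this assay, compound 2 gives 4800 nM and compound 3 gives 8500 nM, and these two numbers lie within the scatter of each other. Compound 1 gives > 25000 nM, which is a limit and not a number.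

The next compound, compound 4 `C=C(CC)C(=O)c1ccc(OCC(=O)NCO[N+](=O)[O-])c(Cl)c1Cl`, has not yet been measured. It carries (nitrooxy)methyl in place of 1-(ethoxycarbonyl)-2-sulfanylethyl on an amide-type nitrogen.

For the measured compounds named here, no measured pair isolates this change, so the expectation rests on a thin comparison. Compound 2 at 4800 nM and compound 3 at 8500 nM differ in the group on that nitrogen, yet their numbers stay close. Compound 1 goes against this pattern, since it gave no number at all. A step of a 1.3-fold higher number from compound 2 to compound 4 (0.10 log units; within the scatter) is expected, which would not go beyond the scatter. For compound 4 the estimated value is 6000 nM, with an expected range from 2000 nM to 18000 nM.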

Compound 4, half-maximal effective concentration: 4100 nM
Compound 4: middle estimate off by 1.5-fold (0.17 log units), on the high side; measured number inside the range.
By their numbers in this assay, from the lowest: compounds 4, 2 and 3 (each within the scatter of the next, the first and the last beyond it). At a limit, above all of these: compound 1.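

In this assay, replacing 1-(ethoxycarbonyl)-2-sulfanylethyl with (nitrooxy)methyl on the amide-type nitrogen gives a 1.2-fold lower number from compound 2 to compound 4 (0.07 log units; within the scatter). For the compounds shown here, this is the first step at this position that can be read directly, and it shows that a group of 8 heavy atoms carrying sulfur and a hydrogen-bond donor can give way to one of 5 heavy atoms with no such donor, with no shift beyond the scatter. Compound 1 remains a limit and not a number, so it adds no step here: the limit of > 25000 nM in this assay, at which 1 of the 4 values shown sits.

The compounds shown leave open whether the nitrooxy group or the sulfanyl group matters at all, since a plain methyl on that nitrogen would be needed to tell. They also leave open how a longer chain ending in nitrooxy, or one ending in an amine, would read.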